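Methyl in place of bromo on the triazole-linked phenyl ring

The compounds below may be only part of what the source reports. "The series", "measured", "known", "first", "only" and "open" are said of these compounds alone.

In a functional assay on A549 cells (Homo sapiens) for cytotoxicity, read by MTT assay, with a stated time of 4 days (a lower number here means a stronger inhibitor, a higher number a weaker inhibitor), compound 1 `C=C1C(=O)[C@]23C[C@@]1(O)CC[C@H]2c1ccc(OS(=O)(=O)c2ccc(C)cc2)c(C)c1[C@@H]3Cn1cc(-c2ccc(Br)cc2)nn1` gives 1630 nM, the lowest of the two numbers shown. Compound 2 `C=C1C[C@]23C[C@@]1(O)CC[C@H]2c1ccc(O)c(C)c1[C@@H]3Cn1cc(-c2ccc(C(F)(F)F)cc2)nn1`, a related compound with a different substitution pattern, gives 10400 nM in this assay. Compound 3 `Cc1c(O)ccc2c1[C@H](Cn1cc(-c3ccc(C(F)(F)F)cc3)nn1)[C@@]13CC(=O)[C@@](C)(CC[C@@H]21)C3` gives > 20000 nM in this assay, which is a limit of the measurement rather than a number.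

Compound 4 `C=C1C(=O)[C@]23C[C@@]1(O)CC[C@H]2c1ccc(OS(=O)(=O)c2ccc(C)cc2)c(C)c1[C@@H]3Cn1cc(-c2ccc(C)cc2)nn1` differs from compound 1 by a single change: methyl in place of bromo on an aromatic carbon. Going by the values given here, no pair of measured compounds isolates this kind of swap, so the expected step from one to the other, a 1.2-fold higher number from compound 1 to compound 4 (0.09 log units; within the scatter), is expected to stay within the ordinary scatter of repeated measurements, in no firm direction. Compound 4 is therefore estimated at 2000 nM, with a range from 800 nM to 5000 nM.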

Compound 4, half-maximal inhibitory concentration: 1830 nM
Estimate against measurement, compound 4: 1.1-fold (0.04 log units) above; low and high end bracket the measured number.
By their numbers in this assay, from the lowest: compounds 1 and 4 (each within the scatter of the next); then compound 2. At a limit, above all of these: compound 3.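

In this assay the swap of bromo for methyl gives a 1.1-fold higher number from compound 1 to compound 4 (0.05 log units; within the scatter) and so no real change. This is the first comparison among these compounds that differs in one place only. It shows that, with the rest of compound 1 kept, the bromine itself is not needed at this position to hold the number, since a methyl group serves equally well.

On these data alone, whether an amine or a carboxylic acid at this position would hold the number as well remains open. Nothing measured here says why bromo and methyl read alike.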